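Swapping tert-butyl for an aryl group in compound 4

The compounds below may be only part of what the source reports. "The series", "measured", "known", "first", "only" and "open" are said of these compounds alone.

Three compounds share one core and differ in a single group. In a functional assay for agonist activity at Glucose-dependent insulinotropic receptor (Homo sapiens) (a higher number here means that more compound is needed for the effect, a lower number that less compound is needed), compound 1 `CCc1noc(C2CCN(c3ncnc(Nc4ccc(S(C)(=O)=O)cc4)c3[N+](=O)[O-])CC2)n1` gives 10 nM, compound 2 `CS(=O)(=O)c1ccc(Nc2ncnc(N3CCC(c4nc(CC5CC5)no4)CC3)c2[N+](=O)[O-])cc1` gives 160 nM, and compound 3 `CC(C)(C)c1noc(C2CCN(c3ncnc(Nc4ccc(S(C)(=O)=O)cc4)c3[N+](=O)[O-])CC2)n1` gives 1.5 nM, the lowest number of the three. Compound 4 `CS(=O)(=O)c1ccc(Nc2ncnc(N3CCC(c4nc(-c5cccc(C(F)(F)F)c5)no4)CC3)c2[N+](=O)[O-])cc1` carries 3-(trifluoromethyl)phenyl in place of tert-butyl on an aromatic carbon. Among the measured compounds shown here, two measured steps touch this position: a 6.7-fold lower number from compound 1 to compound 3 (0.82 log units; beyond the scatter) and a 110-fold lower number from compound 2 to compound 3 (2.03 log units; beyond the scatter), so the group here moves the number strongly, and the cyclopropylmethyl of compound 2 gave the highest number. For the measured compounds named here, a six-membered aromatic ring is a new kind of group with no direct precedent, so a shift away from compound 3 is expected, most likely upward. Compound 4 is estimated at 20 nM, between 3 nM and 150 nM, which is the expected step of a 13-fold higher number from compound 3 to compound 4 (1.12 log units; beyond the scatter).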

Compound 4, half-maximal effective concentration: 24 nM
Compound 4: the middle estimate sits 1.2-fold (0.08 log units) below what was measured, and the stated range covers the measured number.
By their numbers in this assay, from the lowest: compound 3; then compound 1; then compound 4; then compound 2.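

In this assay, a six-membered aromatic ring on this carbon still gives a measurable effect: 3-(trifluoromethyl)phenyl falls short of tert-butyl, a 16-fold higher number from compound 3 to compound 4 (1.20 log units; beyond the scatter), but improves on cyclopropylmethyl, a 6.7-fold lower number from compound 2 to compound 4 (0.82 log units; beyond the scatter). It also falls short of ethyl, a 2.4-fold higher number from compound 1 to compound 4 (0.38 log units; beyond the scatter), so among these four compounds the number does not simply follow the size of the group. Nothing measured here explains these shifts.

The compounds shown leave open how much of the result comes from the ring and how much from the trifluoromethyl. A plain phenyl or a methoxyphenyl would help separate the two.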